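The compounds below may be only part of what the source reports. "The series", "measured", "known", "first", "only" and "open" are said of these compounds alone.

Working notes on the series, values from a functional assay on HepG2 cells (Homo sapiens) for antiproliferative activity, read by CCK-8 assay, with a stated time of 48 h; a higher number here means a weaker inhibitor, a lower number a stronger inhibitor
Compound 1 `COc1ccc(/C=C\c2cc(OC)c(OC)c(OC)c2)cc1OCc1ccc(CNC(C)(C)C(=O)O)cc1` gives 6500 nM
Compound 2 `COc1ccc(/C=C\c2cc(OC)c(OC)c(OC)c2)cc1OCc1ccc(CN2CCCC[C@@H]2C(=O)O)cc1` gives > 10000 nM (a limit of the assay)
Compound 3 `COc1ccc(/C=C\c2cc(OC)c(OC)c(OC)c2)cc1OCc1ccc(CN2CC[C@H](O)C2)cc1` gives 6600 nM

Compound 3 at 6600 nM stands level with compound 1 at 6500 nM, the two within the scatter of each other. For the measured compounds named here, the only other reading is the limit of compound 2.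

Compound 4 `COc1ccc(/C=C\c2cc(OC)c(OC)c(OC)c2)cc1OCc1ccc(CN2CC[C@@H](C(=O)O)C2)cc1` has 3-carboxypyrrolidin-1-yl in place of 3-hydroxypyrrolidin-1-yl on a saturated chain carbon bound to an aromatic carbon.

The closest evidence is a 1.0-fold higher number from compound 1 to compound 3 (0.01 log units; within the scatter), where a carboxy-bearing amine gives way to the same 3-hydroxypyrrolidin-1-yl group. As far as these compounds go, the two steps that touch the limit, an at least 1.5-fold higher number from compound 1 to compound 2 (0.18 log units; that floor lies within the scatter) and an at least 1.5-fold lower number from compound 2 to compound 3 (0.18 log units; that floor lies within the scatter), have floors inside the scatter, so their true size stays open. Going by the values given here, no measured step goes beyond the scatter, so none is expected here in this assay. Compound 2 also carries a carboxy group and stands at > 10000 nM, which is a limit, so the middle leans slightly toward a higher number and a reported limit remains possible.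

The expected change is a 1.2-fold higher number from compound 3 to compound 4 (0.08 log units; within the scatter), within the scatter. For compound 4 the estimated value is 8000 nM, with an expected range of 4000 nM to 15000 nM.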

Compound 4, half-maximal inhibitory concentration: 2300 nM
For compound 4 the middle estimate is 3.5-fold (0.54 log units) above the measured one, and the stated range ends above it.
By their numbers in this assay, from the lowest: compound 4; then compounds 1 and 3 (each within the scatter of the next). At a limit, above all of these: compound 2.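

In this assay, for the compounds shown here, 3-carboxypyrrolidin-1-yl in place of 3-hydroxypyrrolidin-1-yl on a saturated chain carbon bound to an aromatic carbon gives a 2.9-fold lower number from compound 3 to compound 4 (0.46 log units; beyond the scatter), a step beyond the scatter, whereas the steps among the earlier compounds all lay within it or had floors within it. A carboxy group alone does not account for the result, as compound 1 and compound 2 also carry one and compound 4 stands apart from both, with a 2.8-fold lower number from compound 1 to compound 4 (0.45 log units; beyond the scatter) and an at least 4.3-fold lower number from compound 2 to compound 4 (0.63 log units; beyond the scatter), which makes compound 4 the strongest inhibitor of the four here. The reading of compound 2 is a limit, so the step from it gives only a floor: the limit of > 10000 nM in this assay, at which 1 of the 4 values shown sits.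

The compounds shown leave open whether a methyl ester or a primary amide in place of the carboxy group on the pyrrolidine ring would keep this number. They also leave open whether the opposite configuration at the defined stereocentre, or 3-carboxyazetidin-1-yl or 4-carboxypiperidin-1-yl at this same place, would do the same.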